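This account rests on a few compounds, and the source may have more. Where it says the series, first, only, none or still open, it means among the compounds named here.

Of the compounds shown here, two have been tested in an assay on Sf9 cells for inhibition of protein deacetylase HDAC6 (Homo sapiens), read by fluorescence, with a stated time of 90 min (on this read-out lower numbers stand for stronger inhibition and higher numbers for weaker inhibition), and both reached only the upper limit of the assay rather than a number. Compound 1, `Cc1cc(C)cc(C(=O)N(CCCCCC(=O)Nc2ccccc2N)CC(=O)NC2CCCCC2)c1`, gives > 10000 nM in this assay, which is a limit. Compound 2, `Cc1cc(C)cc(C(=O)N(CC(=O)NCc2ccccc2)Cc2ccc(C(=O)Nc3cc(-c4ccccc4)ccc3N)cc2)c1`, gives > 10000 nM in this assay, also a limit. Within the data shown here, compound 2 therefore stands at the same place as the only other value shown, described by the limit of > 10000 nM in this assay, at which 2 of the 2 values shown sit.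

Compound 3, `CN(C)c1ccc(C(=O)N(CC(=O)NCc2ccccc2)Cc2ccc(C(=O)Nc3cc(-c4ccccc4)ccc3N)cc2)cc1`, is made from compound 2 by one change: 4-(dimethylamino)phenyl in place of 3,5-dimethylphenyl on a carbonyl carbon. Among the measured compounds shown here, no measured pair shows what such a change does here, so the expectation rests on compound 2 alone. The step from compound 2 to compound 3 in this assay is expected to be small, with no clear direction beyond the usual scatter, which a step that the limit leaves unreadable from compound 2 to compound 3 reflects. Compound 3 is estimated to give about 15000 nM in this assay, most likely again a limit, within the range 5000 nM to 50000 nM.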

Compound 3, half-maximal inhibitory concentration: > 10000 nM
Compound 3: only a limit was reported; the forecaster's own chance of this, stated with the estimate: 85%; the middle value is on the limit's open side.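

In this assay compound 3 gives > 10000 nM, a limit like that of compound 2, so the step between these two compounds cannot be read. Whether 4-(dimethylamino)phenyl in place of 3,5-dimethylphenyl changes inhibition at all stays open, as does the actual number for any compound shown.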